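Trifluoromethyl in Place of Methyl on the Amide Ring

A few compounds are considered here, and "the series" means these few. Any claim that something is new, unique, unknown or untested is made for them only; others in the source may bear on it.

Measured so far:
compound 1, `COC(=O)N[C@H]1Cc2ccc(NC(=O)c3ccccc3-c3ccc(C(F)(F)F)cc3)cc2C1`: 68 nM
compound 2, `COC(=O)N[C@@H]1Cc2ccc(NC(=O)c3ccccc3-c3ccc(C(F)(F)F)cc3)cc2C1`: 110 nM
compound 3, `COC(=O)N[C@H]1Cc2ccc(NC(=O)c3cc(C)ccc3-c3ccc(C(F)(F)F)cc3)cc2C1`: 170 nM

These three compounds were tested in an assay on isolated protein for inhibition of microsomal triglyceride transfer protein large subunit (Homo sapiens); on this read-out higher numbers stand for weaker inhibition and lower numbers for stronger inhibition. Compound 3 has the highest number of the three. The step of a 2.5-fold higher number from compound 1 to compound 3 (0.40 log units; beyond the scatter) is the only one here that passes beyond the scatter, while compound 3 and compound 2 lie within the scatter of each other. Compounds 1 and 2 differ only in how one stereocentre is drawn (the fact that compounds 1 and 2 differ only in the configuration as drawn), and the step of a 1.6-fold higher number from compound 1 to compound 2 (0.21 log units; within the scatter) stays within the scatter.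

Compound 4, `COC(=O)N[C@H]1Cc2ccc(NC(=O)c3cc(C(F)(F)F)ccc3-c3ccc(C(F)(F)F)cc3)cc2C1`, is the next compound. Relative to compound 3 the change is trifluoromethyl in place of methyl on an aromatic carbon. For the measured compounds named here, only one measured step bears on this aromatic carbon: the step of a 2.5-fold higher number from compound 1 to compound 3 (0.40 log units; beyond the scatter), which put a methyl there and raised the number modestly. Going by the values given here, no measured pair swaps methyl for trifluoromethyl, so the expectation rests on that single step. A number close to or somewhat above that of compound 3 is expected, which amounts to a step of a 1.3-fold higher number from compound 3 to compound 4 (0.11 log units; within the scatter). For compound 4 the estimate in this assay is 220 nM, with a range from 80 nM to 600 nM.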

Compound 4, half-maximal inhibitory concentration: 410 nM
Beside the measured number, compound 4's estimate is 1.9-fold (0.27 log units) below it; low and high end bracket the measured number.
By their numbers in this assay, from the lowest: compounds 1, 2 and 3 (each within the scatter of the next, the first and the last beyond it); then compound 4.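

At this aromatic carbon, para to a 4-(trifluoromethyl)phenyl group, the identity of the added group matters and not only the loss of hydrogen: in this assay, trifluoromethyl in place of methyl gives a 2.4-fold higher number from compound 3 to compound 4 (0.38 log units; beyond the scatter) and so adds a second clear rise to the one seen with methyl. Trifluoromethyl in place of hydrogen gives a 6.0-fold higher number from compound 1 to compound 4 (0.78 log units; beyond the scatter) as the total change at this carbon, so hydrogen, methyl and trifluoromethyl there give rising numbers in that order. Nothing available here explains that order.

Still open, from the compounds shown here alone, is how an amine, a methoxy group or a single fluorine atom on this carbon would compare with hydrogen, methyl and trifluoromethyl. Also open, going by these compounds, is whether compound 2, with the other drawn configuration, would respond to trifluoromethyl at this carbon in the same way.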